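Swapping the anilino aryl group on a nitro-pyrimidine scaffold

A few compounds are considered here, and "the series" means these few. Any claim that something is new, unique, unknown or untested is made for them only; others in the source may bear on it.

Among the compounds with values here, compound 1 `CCOC(=O)CNc1nc(Nc2ccc(Cl)cc2)ncc1[N+](=O)[O-]` gives 55500 nM in a functional assay on MDA-MB-231 cells (Homo sapiens) for antiproliferative activity, read by MTT assay, with a stated time of 48 h (a lower number here means a stronger inhibitor, a higher number a weaker inhibitor), the highest of the two numbers recorded; the nearest is compound 2 `CCOC(=O)CN(Cc1ccccc1)c1nc(Nc2ccc(Cl)cc2)ncc1[N+](=O)[O-]`, which gives 34400 nM, and the only step measured, a 1.6-fold lower number from compound 1 to compound 2 (0.21 log units; within the scatter), is within the scatter. Compound 3 `CCOC(=O)CNc1nc(Nc2cccc(OC)c2)ncc1[N+](=O)[O-]` differs from compound 1 by 3-methoxyphenyl in place of 4-chlorophenyl on a nitrogen on an aromatic ring. Within the data shown here, no measured step touches the aryl group on that nitrogen, so no direction is expected beyond the scatter. For compound 3 an estimate of 55000 nM, between 15000 nM and 200000 nM, is given. The expected step is thus a 1.0-fold lower number from compound 1 to compound 3 (0.00 log units; within the scatter).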

Compound 3, half-maximal inhibitory concentration: 31300 nM
The estimate for compound 3 lay 1.8-fold (0.24 log units) above the measured number, and the stated range covers the measured number.
By their numbers in this assay, from the lowest: compounds 3, 2 and 1 (each within the scatter of the next).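

In this assay, putting 3-methoxyphenyl in place of 4-chlorophenyl on a nitrogen on an aromatic ring gives a 1.8-fold lower number from compound 1 to compound 3 (0.25 log units; within the scatter) and so stays within the scatter. The aryl group at this position can therefore change in its substituent and in the ring carbon that carries it without the numbers separating the two compounds. Nothing measured here offers an explanation for this result.

As far as these compounds go, whether an aryl group carrying an amine or a carboxylic acid would move the number beyond the scatter remains open. So does whether any aryl group on this nitrogen gives a markedly stronger inhibitor.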